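Compound 2 and its propylcarbonyl ester, compound 4

A few compounds are considered here, and "the series" means these few. Any claim that something is new, unique, unknown or untested is made for them only; others in the source may bear on it.

Compound 1 `OC[C@H]1C[C@@H](n2cnc3c(Cl)ncnc32)[C@@H]1CO` gives > 200000 nM (a limit)
Compound 2 `OC[C@H]1O[C@@H](n2cnc3c(Cl)ncnc32)C[C@@H]1O` gives 173000 nM
Compound 3 `O=C(OCC(CO)CCn1cnc2c(Cl)ncnc21)c1ccccc1` gives 108000 nM

In an ADME assay on Huh-7 cells (Homo sapiens) for cytotoxicity, read by XTT assay (on this read-out higher numbers stand for lower toxicity in this test and lower numbers for higher toxicity in this test), compound 2 gives 173000 nM and compound 3 gives 108000 nM so these two numbers lie within the usual scatter of each other. For compound 1 the read-out in this assay is only a limit (> 200000 nM) and not a number.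

Compound 4 `CCCC(=O)OC[C@H]1O[C@@H](n2cnc3c(Cl)ncnc32)C[C@@H]1O` has not yet been measured. It differs from compound 2 by propylcarbonyl in place of hydrogen on an oxygen on a saturated carbon and is thus an ester. Among the measured compounds shown here, no measured pair shows this change directly. The nearest guide is compound 3, also an ester, with its value of 108000 nM lying within the scatter of the number for compound 2. No step beyond the scatter is therefore expected in this assay and the estimated step is a 1.3-fold lower number from compound 2 to compound 4 (0.12 log units; within the scatter) in size. For compound 4 the estimated value is 130000 nM and the expected range runs from 60000 nM to 200000 nM by this estimate.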

Compound 4, half-maximal cytotoxic concentration: > 200000 nM
Compound 4: only a limit was reported; the forecaster's own chance of this, stated with the estimate: 25%; middle value at least 1.5-fold (0.18 log units) away from the limit.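

In this assay, the change from hydrogen to propylcarbonyl on this oxygen can now be read directly, which compound 3 could not offer, as it differs from compound 2 in more than one place: the result is an at least 1.1-fold higher number from compound 2 to compound 4 (0.06 log units; that floor lies within the scatter). This ester therefore brings no drop in the number beyond the scatter, so adding propylcarbonyl here shows no sign of higher toxicity in this test. Compound 4 gives only a limit, so the true size of the step stays unknown, and compound 1 gives a limit at the same point: the limit of > 200000 nM in this assay, at which 2 of the 4 values shown sit.

The compounds shown leave open whether a longer chain in place of propylcarbonyl would give the same result. They also leave open what an amine or a carboxylic acid carried on that chain would do.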